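The source may hold more compounds than are shown below. What is called first, only, known or untested is meant among the compounds shown, and "the series" means these compounds.

Compound 1 `O=C(NCc1ccc(-c2noc(CCC3CC3)n2)cc1)[C@H]1NCC[C@@H]1O` has been measured in a physicochemical assay for solubility, at pH 7.4; on this read-out lower numbers stand for lower solubility and higher numbers for higher solubility. In this assay compound 1 gives > 50 ug/mL, which is a limit of the assay rather than a number. Only a limit or a range is therefore known for compound 1, and the limit of > 50 ug/mL in this assay, at which 1 of the 3 values shown sits, marks where it sits among the three values in hand. Two further compounds have been measured. Compound 2 `CCCCCCCc1nc(-c2ccc([C@@H](NC(=O)[C@H]3NCC[C@@H]3O)C(C)C)cc2)no1` gives 3 ug/mL in this assay, and compound 3 `CCCCCCCc1noc(-c2ccc(CNC(=O)[C@H]3NCC[C@@H]3O)cc2)n1` gives 3 ug/mL in this assay. Among the measured compounds shown here, both carry a heptyl chain, and neither differs from compound 1 in one place only, so no single step between measured compounds can be read off.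

Compound 4 `O=C(NCc1ccc(-c2noc(C3CCCCC3)n2)cc1)[C@H]1NCC[C@@H]1O` has not yet been measured in this assay. It differs from compound 1 by cyclohexyl in place of 2-cyclopropylethyl on an aromatic carbon. For the measured compounds named here, no measured step covers a change of this kind. Compound 1 stands at the limit of this assay. Compound 3, with its heptyl chain, gives 3 ug/mL, and the cyclohexyl group of compound 4 is a shorter departure from compound 1 than that chain. The step from compound 1 to compound 4 is expected to be a modest fall, an at least 1.6-fold lower number from compound 1 to compound 4 (0.22 log units; that floor lies within the scatter), possibly no larger than the scatter. Compound 4 is therefore estimated at 30 ug/mL, in a range from 10 ug/mL to 60 ug/mL.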

Compound 4, solubility: > 50 ug/mL
Compound 4: a limit, no number; the forecaster's own chance of this, stated with the estimate: 40%; at least 1.6-fold (0.22 log units) between middle value and limit.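

In this assay compound 4 ends at a limit of the assay and not a number, as compound 1 does, so no step between compound 1 and compound 4 can be read: the limit of > 50 ug/mL in this assay, at which 2 of the 4 values shown sit.

The compounds shown leave open how far either compound lies past that limit, and whether cyclohexyl and 2-cyclopropylethyl differ at all in this assay.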